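Ethyl on the hydroxy oxygen of compound 3

The source may hold more compounds than are shown below. What is called first, only, known or untested is meant among the compounds shown, and "the series" means these compounds.

In a functional assay on MCF7 cells (Homo sapiens) for antiproliferative activity, read by sulforhodamine B assay, with a stated time of 72 h (on this read-out higher numbers stand for weaker inhibition and lower numbers for stronger inhibition), compound 1 (`COc1c(O)cc2occ(-c3csc4ccccc34)c(=O)c2c1O`) reads > 10000 nM as a limit of the assay. Compound 3 (`COc1cc2occ(-c3csc4ccccc34)c(=O)c2c(OC)c1O`) reads > 10000 nM as a limit too, not a number. Compound 3 thus stands at the limit of > 10000 nM in this assay, at which 2 of the 3 values shown sit, on this read-out. Compound 2 (`COc1cc2occ(-c3csc4ccccc34)c(=O)c2c(OC)c1OC`) gives 740 nM as a measured number.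

Compound 4 (`CCOc1c(OC)cc2occ(-c3csc4ccccc34)c(=O)c2c1OC`) differs from compound 3 by ethyl in place of hydrogen on an oxygen on an aromatic ring (ethyl in place of hydrogen on an oxygen on an aromatic ring, hydroxy to ethoxy). Within the data shown here, one measured step bears on this: an at least 13-fold higher number from compound 2 to compound 3 (1.13 log units; beyond the scatter) for hydrogen in place of methyl on an oxygen on an aromatic ring. With that step as the guide, a large change toward a lower number is expected in this assay when ethyl replaces the hydrogen. Among the measured compounds shown here, a full return to the level of compound 2 (740 nM) is not assumed, since no ethyl compound has been measured. The expected change is an at least 6.6-fold lower number from compound 3 to compound 4 (0.82 log units; beyond the scatter) by this estimate. For compound 4 the estimated value is 1500 nM with an expected range of 400 nM to 6000 nM in this assay.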

Compound 4, half-maximal inhibitory concentration: 4000 nM
Beside the measured number, compound 4's estimate is 2.7-fold (0.43 log units) below it; the range from low to high includes it.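

In this assay, ethyl on the hydroxy oxygen brings back a measured number: an at least 2.5-fold lower number from compound 3 to compound 4 (0.39 log units; beyond the scatter). The effect of capping this oxygen is therefore not confined to methyl, but ethoxy does not match methoxy: a 5.4-fold higher number from compound 2 to compound 4 (0.73 log units; beyond the scatter). This position accepts either alkyl group on the oxygen, with the extra methyl of the ethyl group giving up part of the gain, while the hydroxy end of the comparison remains a limit of the assay: the limit of > 10000 nM in this assay, at which 2 of the 4 values shown sit.

On these data alone, whether the number keeps rising with a longer chain such as propyl or butyl on this oxygen, or how a chain ending in an amine or a carboxylic acid would read, stays open. The compounds shown give no cause for the order of methoxy, ethoxy and hydroxy in this assay.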